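The source may hold more compounds than are shown below. What is called first, only, known or untested is meant among the compounds shown, and "the series" means these compounds.

Working notes on the bis(trifluoromethyl)benzenesulfonamide series.

Three compounds carry numbers in a functional assay on PANC-1 cells (Homo sapiens) for inhibition, read by MTT assay, with a stated time of 72 h; on this read-out lower numbers stand for stronger inhibition of growth and higher numbers for weaker inhibition of growth. Compound 1 `O=S(=O)(NCCNCc1cccc2ccccc12)c1cc(C(F)(F)F)cc(C(F)(F)F)c1` gives 24000 nM, compound 3 `COc1ccc(CNCCCNS(=O)(=O)c2cc(C(F)(F)F)cc(C(F)(F)F)c2)cc1OC` gives 18000 nM, and compound 2 `O=S(=O)(NCCNCc1ccc(-c2ccccc2)cc1)c1cc(C(F)(F)F)cc(C(F)(F)F)c1` gives 4200 nM. Compound 2 thus stands at the lowest number of the three, with compound 3 the nearer of the other two and compound 1 the further, both gaps beyond the usual scatter of repeated measurements. No two of these three differ in one place only, so their pairwise gaps are read as what the values show and nothing more.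

Compound 4 `CC(C)(C)c1ccc(CNCCNS(=O)(=O)c2cc(C(F)(F)F)cc(C(F)(F)F)c2)cc1` has not been measured in this assay. Against compound 2 the change is tert-butyl in place of phenyl on an aromatic carbon. Going by the values given here, with no single-place step available among the measured compounds to calibrate this exchange, only a modest shift is expected, plausibly toward a somewhat higher number, but a step within the scatter would not surprise. For compound 4 the estimate in this assay is 6500 nM, with a range from 2500 nM to 17000 nM. This estimate amounts to an expected step of a 1.5-fold higher number from compound 2 to compound 4 (0.19 log units; within the scatter).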

Compound 4, concentration for 50% growth inhibition: 13000 nM
The estimate for compound 4 lay 2.0-fold (0.30 log units) below the measured number; the measured number falls inside the stated range.
By their numbers in this assay, from the lowest: compound 2; then compounds 4, 3 and 1 (each within the scatter of the next).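

In this assay, going by these compounds alone, tert-butyl in place of phenyl on an aromatic carbon, para to a large group, gives the first single-place step: a 3.1-fold higher number from compound 2 to compound 4 (0.49 log units; beyond the scatter). Phenyl at this position therefore cannot be exchanged for tert-butyl without a change beyond the scatter, whereas 4-(tert-butyl)phenyl in place of naphthalen-1-yl on a saturated chain carbon bound to an amine nitrogen gives a 1.8-fold lower number from compound 1 to compound 4 (0.27 log units; within the scatter), which stays within it. Nothing at hand bears on what lies behind either step.

The compounds shown leave open how a cyclohexyl group, a pyridyl ring or a methoxy group on this aromatic carbon would read against phenyl and tert-butyl. Also open, as far as these compounds go, is whether the same exchange gives a like step on a longer chain in the core of compound 2.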